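The compounds below may be only part of what the source reports. "The series", "measured", "known", "first", "only" and "open" are said of these compounds alone.

Within the data shown here, compound 2, `COc1ccc2nc(Nc3ccnc(Nc4ccc(S(N)(=O)=O)cc4)n3)sc2c1`, is the one compound here with a numerical reading: in a functional assay on MCF7 cells (Homo sapiens) for antiproliferative activity, read by MTT assay, with a stated time of 48 h (a lower number here means a stronger inhibitor, a higher number a weaker inhibitor), compound 2 gives 11000 nM. Compound 1, `CS(=O)(=O)c1ccc(Nc2nccc(Nc3nc4ccc(F)cc4s3)n2)cc1`, differs from compound 2 in more than one place. In this assay compound 1 reaches only a limit, > 60000 nM, so the reading is a limit of the assay rather than a number, and the limit of > 60000 nM in this assay, at which 1 of the 2 values shown sits, marks where it sits.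

Compound 3, `COc1ccc2nc(Nc3ccnc(Nc4ccc(S(C)(=O)=O)cc4)n3)sc2c1`, is not yet measured. It keeps the whole of compound 2 apart from one change: methyl in place of amino on a sulfonyl sulfur. That is, the sulfamoyl group of compound 2 becomes a methylsulfonyl group. Among the measured compounds shown here, no measured pair shows this exact swap on its own, so the size of the step rests on an expectation only. The expected step from compound 2 to compound 3 is a moderate weakening, a 2.7-fold higher number from compound 2 to compound 3 (0.44 log units; beyond the scatter), just beyond the usual scatter. Compound 3 is therefore estimated at 30000 nM, with a likely range from 8000 nM to 120000 nM.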

Compound 3, half-maximal inhibitory concentration: > 50000 nM
Compound 3 ended at the assay's limit (the forecaster's own chance of this, stated with the estimate: 40%); middle value at least 1.6-fold (0.22 log units) from the limit.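

In this assay compound 3 gives > 50000 nM, which is a limit of the assay and not a number. Among these compounds, compound 2 and compound 3 differ in one place only, so this is the first clean reading of the change from sulfamoyl to methylsulfonyl, and it amounts to an at least 4.5-fold higher number from compound 2 to compound 3 (0.65 log units; beyond the scatter); on this core, the measurable activity is lost when methyl replaces amino on the sulfonyl sulfur, and the true step may be larger than this. The step between compound 1 and compound 3, where methoxy replaces fluoro on an aromatic carbon, cannot be read, since both compounds end at limits.

The compounds shown leave open whether a methylamino or dimethylamino group on the same sulfur would keep the reading of compound 2. They also leave open what fluoro in place of methoxy does while sulfamoyl stays in place.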